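From 1,1-dimethylpropyl to pyridin-4-yl on a carbonyl carbon

The source may hold more compounds than are shown below. What is called first, only, known or untested is meant among the compounds shown, and "the series" means these compounds.

In a functional assay on NCI-H460 cells (Homo sapiens) for cytotoxicity, read by MTT assay, with a stated time of 48 h (a lower number here means a stronger inhibitor, a higher number a weaker inhibitor), compound 1 `C=C1C(=O)O[C@H]2CC3=C[C@H](C/C(C)=C/[C@@H](OC(=O)CCCCBr)[C@H]12)OC3=O` reaches only a limit, > 10000 nM. Compound 2 `C=C1C(=O)O[C@H]2CC3=C[C@H](C/C(C)=C/[C@@H](OC(=O)CC4CCCCC4)[C@H]12)OC3=O` gives 2000 nM. Compound 3 `C=C1C(=O)O[C@H]2CC3=C[C@H](C/C(C)=C/[C@@H](OC(=O)C(C)(C)CC)[C@H]12)OC3=O` gives 6100 nM, the higher of the two true numbers. Compound 4 `C=C1C(=O)O[C@H]2CC3=C[C@H](C/C(C)=C/[C@@H](OC(=O)c4ccncc4)[C@H]12)OC3=O` carries pyridin-4-yl in place of 1,1-dimethylpropyl on a carbonyl carbon. Two measured changes at this carbonyl carbon show how far such swaps can move the number: a 3.1-fold higher number from compound 2 to compound 3 (0.48 log units; beyond the scatter) and an at least 1.6-fold lower number from compound 1 to compound 3 (0.21 log units; that floor lies within the scatter). Neither brings in an aromatic ring, so they suggest a scale but no direction. The expected change is a 1.0-fold lower number from compound 3 to compound 4 (0.01 log units; within the scatter), which means no step beyond the scatter is expected. For compound 4 the estimated value is 6000 nM, with an expected range of 2000 nM to 16000 nM.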

Compound 4, half-maximal inhibitory concentration: 5600 nM
For compound 4 the middle estimate is 1.1-fold (0.03 log units) above the measured one; the range from low to high includes it.
By their numbers in this assay, from the lowest: compound 2; then compounds 4 and 3 (each within the scatter of the next). At a limit, above all of these: compound 1.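

An aromatic ring now sits on this carbonyl carbon, and in this assay it does not separate from the 1,1-dimethylpropyl group: a 1.1-fold lower number from compound 3 to compound 4 (0.04 log units; within the scatter). The gap to cyclohexylmethyl remains, with a 2.8-fold higher number from compound 2 to compound 4 (0.45 log units; beyond the scatter), so compound 2 stays apart from both compound 3 and compound 4. The last step starts from a limit and stands only as a floor: an at least 1.7-fold lower number from compound 1 to compound 4 (0.25 log units; that floor lies within the scatter). Compound 1 gives only that limit: the limit of > 10000 nM in this assay, at which 1 of the 4 values shown sits.

Going by these compounds, what a phenyl ring or pyridin-2-yl would give on this carbonyl carbon stays open. So does whether the ring nitrogen of compound 4 plays any part in its number.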